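The compounds below may be only part of what the source reports. "The series", "measured", "known", "first", "only" and "open" are said of these compounds alone.

Compound 1, `N#Cc1ccccc1C1OCC(C/C=C\CCC(=O)O)C(c2cccnc2)O1`: in an assay for inhibition of prostacyclin synthase (Homo sapiens), using microsomes (on this read-out lower numbers stand for stronger inhibition and higher numbers for weaker inhibition), compound 1 gives > 100000 nM, which is a limit of the assay rather than a number.
Compound 2, `O=C(O)CC/C=C\CC1COC(c2ccc(Cl)cc2Cl)OC1c1cccnc1`: in this assay compound 2 gives 2500 nM.
Compound 3, `CC(C)(Oc1ccccc1)C1OCC(C/C=C\CCC(=O)O)C(c2cccnc2)O1`: in this assay compound 3 gives 75000 nM.

Compound 3 stands at the highest of the two numbers, with compound 2 nearest below it: a 30-fold higher number from compound 2 to compound 3 (1.48 log units; beyond the scatter). Compound 4, `Cc1ccc(C#N)c(OC(C)(C)C2OCC(C/C=C\CCC(=O)O)C(c3cccnc3)O2)c1`, differs from compound 3 by 2-cyano-5-methylphenyl in place of phenyl on an oxygen on a saturated carbon. Going by the values given here, none of the measured steps touches this part of the molecule; all of them exchange the aryl group on the saturated ring carbon, as in an at least 40-fold lower number from compound 1 to compound 2 (1.60 log units; beyond the scatter) and an at least 1.3-fold lower number from compound 1 to compound 3 (0.12 log units; that floor lies within the scatter), the latter within the scatter. Among the compounds with values here, the only compound that carries a nitrile on an aryl ring, compound 1, reached the limit (the limit of > 100000 nM in this assay, at which 1 of the 3 values shown sits). The evidence for the step to compound 4 in this assay is therefore thin, and no step beyond the scatter is expected: a 1.1-fold higher number from compound 3 to compound 4 (0.03 log units; within the scatter). Compound 4 is estimated at 80000 nM, between 20000 nM and 300000 nM.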

Compound 4, half-maximal inhibitory concentration: > 100000 nM
Compound 4: a limit, no number; the forecaster's own chance of this, stated with the estimate: 35%; middle value at least 1.2-fold (0.09 log units) away from the limit.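

At the oxygen on a saturated carbon, 2-cyano-5-methylphenyl in place of phenyl gives an at least 1.3-fold higher number from compound 3 to compound 4 (0.12 log units; that floor lies within the scatter), so this first change at the position has only a floor, and that floor does not separate compound 4 from compound 3. What the result does show is that this change brings no stronger inhibition in this assay, since compound 4 reads only as a limit of the assay and not as a number. With it, a second compound with a nitrile on an aryl ring, after compound 1, stands at that limit: the limit of > 100000 nM in this assay, at which 2 of the 4 values shown sit.

Going by these compounds, how far compound 4 really lies from compound 3 stays open, as does whether the nitrile or the methyl accounts for the reading. Also open, on these data alone, is whether an amine or a hydroxyl on that phenyl would lower the number in this assay.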